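The compounds below may be only part of what the source reports. "The series", "measured", "known", "first", "only" and "open" are said of these compounds alone.

Measured so far in an assay on isolated protein for inhibition of serine protease 1 (Bos taurus); a lower number here means a stronger inhibitor, a higher number a weaker inhibitor:

Compound 1 `Cc1c(F)c(Oc2cccc(C(=N)N)c2)nc(Oc2cccc([N+](=O)[O-])c2)c1F`. In this assay compound 1 gives > 5000 nM, which is a limit of the assay and not a number.
Compound 2 `Cc1c(F)c(Oc2cccc(C(=N)N)c2)nc(Oc2cccc(C(=O)N3CCOCC3)c2)c1F`. In this assay compound 2 gives > 5000 nM, again a limit of the assay.
Compound 3 `Cc1c(F)c(Oc2cccc(C(=N)N)c2)nc(Oc2cccc(-n3ccnc3)c2)c1F`. In this assay compound 3 gives 4800 nM.

Compound 1 stands only at a limit in this assay; the limit of > 5000 nM in this assay, at which 2 of the 3 values shown sit, covers it, so its position against the other two cannot be fixed beyond saying that no value in the series is strong. The step considered here leads to compound 4 `Cc1c(Oc2nc(Oc3cccc(C(=N)N)c3)c(F)c(C)c2F)cccc1N(C)C`: 3-(dimethylamino)-2-methylphenyl in place of 3-nitrophenyl on an oxygen on an aromatic ring. The measured steps at the same place are a step that the two limits leave unreadable from compound 1 to compound 2, an at least 1.0-fold lower number from compound 1 to compound 3 (0.01 log units; that floor lies within the scatter) and an at least 1.0-fold lower number from compound 2 to compound 3 (0.01 log units; that floor lies within the scatter). None of them shows a readable change, and every measured value sits at or close to the limit. The step expected in this assay is therefore a number no higher from compound 1 to compound 4 (the limit leaves the size open), with no movement beyond the scatter. Compound 4 is estimated at 5000 nM, within a range from 1500 nM to 16000 nM, and a value reported only as a limit is a real possibility.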

Compound 4, inhibition constant: 5000 nM
For compound 4 middle estimate and measured number coincide at the digits printed, and the stated range covers the measured number.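

In this assay compound 4 gives 5000 nM, a measured number and not a limit, and the step is a number no higher from compound 1 to compound 4 (the limit leaves the size open), and this shows that a 3-(dimethylamino)-2-methylphenyl on this oxygen also leaves the series weak. The value of compound 1 is a limit of the assay, and the size of this step cannot be read. All four groups at this place now stand at or close to the same end of the range: the limit of > 5000 nM in this assay, at which 2 of the 4 values shown sit.

On these data alone, it remains open whether any group on this oxygen can bring the number clearly down, and whether the dimethylamino and the methyl of the entering group count separately. A carboxylic acid or a longer chain ending in an amine at this place would test how far the readings can leave that end of the range.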